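A few compounds are considered here, and "the series" means these few. Any claim that something is new, unique, unknown or untested is made for them only; others in the source may bear on it.

Measured so far in an in vivo ADME assay on the whole organism (strain 129/SvEvBrd x C57BL/6) for pharmacokinetics, with Mus musculus as the target; on this read-out higher numbers stand for higher oral bioavailability and lower numbers for lower oral bioavailability:
compound 1 `CC(O)c1nc([C@@H](O)[C@H](O)[C@H](O)CO)c[nH]1` gives 22%
compound 2 `OC[C@@H](O)[C@@H](O)[C@H](O)c1c[nH]c(-c2ncccn2)n1` gives 7%

Compound 2 stands at 7%, the lower of the two numbers. The next compound, compound 3 `Cn1cnc(-c2nc([C@@H](O)[C@H](O)[C@H](O)CO)c[nH]2)c1`, carries 1-methyl-1H-imidazol-4-yl in place of pyrimidin-2-yl on an aromatic carbon. Among the measured compounds shown here, one measured step bears on this place, a number 15 percentage points lower from compound 1 to compound 2 (beyond the scatter), a modest one beyond the scatter. That step brought in pyrimidin-2-yl for 1-hydroxyethyl, whereas here one aromatic ring replaces another with the same counts, so it gives only a loose guide. For the measured compounds named here, no measured step shows such an exchange between aromatic rings. In this assay the expected change is therefore small, and the estimated step of a number 3 percentage points higher from compound 2 to compound 3 (within the scatter) stays within the scatter. For compound 3 the estimate is 10%, with an expected range from 2% to 24%.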

Compound 3, oral bioavailability: 3%
The estimate for compound 3 lay 7 percentage points above the measured number; measured number inside the range.
By their numbers in this assay, from the lowest: compounds 3 and 2 (each within the scatter of the next); then compound 1.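

In this assay, exchanging pyrimidin-2-yl for 1-methyl-1H-imidazol-4-yl on this aromatic carbon, between two ring nitrogen atoms, gives a number 4 percentage points lower from compound 2 to compound 3 (within the scatter), so a five-membered and a six-membered aromatic ring with the same counts cannot be told apart on this read-out. Putting 1-methyl-1H-imidazol-4-yl in place of 1-hydroxyethyl gives a number 19 percentage points lower from compound 1 to compound 3 (beyond the scatter), which means that both aromatic groups now seen at this place stand beyond the scatter from compound 1. No supporting data bear on why these numbers fall as they do.

As far as these compounds go, it stays open whether the gap to compound 1 goes with losing 1-hydroxyethyl or with bringing in an aromatic ring. An ethyl group, an aminomethyl group or a carboxylic acid at this place could separate the two readings.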